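Hexylamino for methoxy on the carbonyl of compound 2

The source may hold more compounds than are shown below. What is called first, only, known or untested is meant among the compounds shown, and "the series" means these compounds.

Among the measured compounds shown here, in a functional assay on UACC-62 cells (Homo sapiens) for antiproliferative activity (on this read-out lower numbers stand for stronger inhibition of growth and higher numbers for weaker inhibition of growth), compound 2 (`COC(=O)c1cc(/C=C\c2cc(OC)ccc2OC)ccc1OC`) gives 14800 nM, the higher of the two numbers so far. Compound 1 (`CCCCCCNC(=O)c1cc(CCc2cc(O)ccc2O)ccc1O`) gives 3300 nM, a lower number than that of compound 2, and the gap lies beyond the scatter.

Compound 3 (`CCCCCCNC(=O)c1cc(/C=C\c2cc(OC)ccc2OC)ccc1OC`) remains unmeasured. It has hexylamino in place of methoxy on a carbonyl carbon of compound 2: hexylamino in place of methoxy on a carbonyl carbon. The same difference reads methoxycarbonyl to hexylcarbamoyl.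

For the measured compounds named here, no measured pair differs in one place only, so the size of this change has not been observed directly. Going by the values given here, the only guide is compound 1, which also carries hexylcarbamoyl and gives 3300 nM. Compound 1 differs from compound 2 in other places too, so their gap cannot be assigned to that group alone.

A modest 2.5-fold lower number from compound 2 to compound 3 (0.39 log units; beyond the scatter) is expected, toward a lower number and stronger inhibition of growth, with real uncertainty about whether it clears the scatter. For compound 3 the estimated value in this assay is 6000 nM, with an expected range from 1800 nM to 20000 nM.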

Compound 3, concentration for 50% growth inhibition: 25000 nM
Compound 3: middle estimate off by 4.2-fold (0.62 log units), on the low side; the whole stated range lies below it.
By their numbers in this assay, from the lowest: compound 1; then compounds 2 and 3 (each within the scatter of the next).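

In this assay, hexylamino in place of methoxy on a carbonyl carbon gives a 1.7-fold higher number from compound 2 to compound 3 (0.23 log units; within the scatter) and so gives no measurable separation between the two compounds. On this core, then, methoxycarbonyl and hexylcarbamoyl are not told apart by this read-out, even though the change adds a hexyl chain and an amide hydrogen. No supporting data accompany this result that could explain it.

Compound 1 differs from compound 3 in more than one place, so the compounds shown do not tell which of those differences goes with the number of compound 1. From the compounds shown here alone, it also remains open whether this flat result extends to other groups on the same carbonyl carbon, such as a carboxylic acid, a primary amide, or an amide with a longer chain such as octylamino.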